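A few compounds are considered here, and "the series" means these few. Any claim that something is new, unique, unknown or untested is made for them only; others in the source may bear on it.

Working notes on the series. The shared core carries a substituted aromatic ring and an amine in a ring on the opposite side; compound 1, `COc1ccc(-c2cnc3nc(N)nc(N4CCC(C)CC4)c3n2)cc1OC`, and compound 2, `COc1ccc(-c2cnc3nc(N)nc(N4CCN(C(=O)COc5ccccc5)CC4)c3n2)cc1OC`, differ in that ring amine. In a functional assay on cells (T-cell, Homo sapiens) for inhibition (on this read-out lower numbers stand for stronger inhibition and higher numbers for weaker inhibition), compound 1 gives 800 nM, whereas compound 2 gives 4 nM. Compound 2 thus stands at the lower of the two numbers, and its gap to compound 1 lies beyond the scatter. Compound 3, `COc1ccc(-c2cnc3nc(N)nc(N4CCN(c5cc(Cl)cc(Cl)c5)CC4)c3n2)cc1OC`, is not yet measured in this assay. The change from compound 2 to compound 3 is 3,5-dichlorophenyl in place of (phenoxymethyl)carbonyl on an amine nitrogen in a ring. Among the measured compounds shown here, no step of this kind is known from measured pairs, so no direction can be read from the numbers; an expected step of moderate size toward a weaker inhibition, a 5.0-fold higher number from compound 2 to compound 3 (0.70 log units; beyond the scatter), is entered as a working guess. In this assay compound 3 is therefore expected to give about 20 nM, in a range from 3 nM to 150 nM.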

Compound 3, half-maximal inhibitory concentration: 3400 nM
Estimate against measurement, compound 3: 170-fold (2.23 log units) below; measured number above the stated range.
By their numbers in this assay, from the lowest: compound 2; then compound 1; then compound 3.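

In this assay the group on the amine nitrogen in a ring proves decisive: 3,5-dichlorophenyl in place of (phenoxymethyl)carbonyl gives an 850-fold higher number from compound 2 to compound 3 (2.93 log units; beyond the scatter), although each group holds one six-membered aromatic ring of carbon only. An aromatic ring at this place is thus not enough to keep the low number of compound 2, and the change also removes the carbonyl and 2 hydrogen-bond acceptors and brings in 2 chlorine atoms. Nothing at hand shows which of these differences accounts for the step.

From the compounds shown here alone, it remains open whether the loss of the carbonyl link or the arrival of the chlorine atoms carries the step. A plain phenyl or a benzoyl group on the same nitrogen would help separate the two.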